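Anilide substituent change on a shared core: methyl to methoxy

The compounds below may be only part of what the source reports. "The series", "measured", "known", "first", "only" and "open" are said of these compounds alone.

Measured compounds:
compound 1 `O=C(CCC(=O)OCCCCCCSc1ccc([N+](=O)[O-])c2nonc12)Nc1ccccc1F`: in a functional assay on 143B cells (Homo sapiens) for inhibition, read by MTT assay, with a stated time of 72 h (a higher number here means a weaker inhibitor, a lower number a stronger inhibitor), compound 1 gives 3030 nM
compound 2 `O=C(CCC(=O)OCCCCCCSc1ccc([N+](=O)[O-])c2nonc12)Nc1ccc(F)cc1`: in this assay compound 2 gives 2500 nM
compound 3 `Cc1ccc(NC(=O)CCC(=O)OCCCCCCSc2ccc([N+](=O)[O-])c3nonc23)cc1`: in this assay compound 3 gives 3250 nM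

Compound 3 has the highest of the three numbers, but the gaps are small: a 1.1-fold higher number from compound 1 to compound 3 (0.03 log units; within the scatter) and a 1.3-fold higher number from compound 2 to compound 3 (0.11 log units; within the scatter), both within the scatter. Compound 4 `COc1ccc(NC(=O)CCC(=O)OCCCCCCSc2ccc([N+](=O)[O-])c3nonc23)cc1` differs from compound 3 by methoxy in place of methyl on an aromatic carbon. Within the data shown here, no measured step exchanges methyl for methoxy; the only step at this position, a 1.3-fold higher number from compound 2 to compound 3 (0.11 log units; within the scatter), stayed within the scatter, as did a 1.2-fold lower number from compound 1 to compound 2 (0.08 log units; within the scatter). The change from compound 3 to compound 4 is therefore expected to give no step beyond the scatter in this assay, roughly a 1.1-fold lower number from compound 3 to compound 4 (0.03 log units; within the scatter). For compound 4 the estimate is 3000 nM, with a range from 1500 nM to 6500 nM.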

Compound 4, half-maximal inhibitory concentration: 3060 nM
The estimate for compound 4 lay 1.0-fold (0.01 log units) below the measured number; measured number inside the range.
By their numbers in this assay, from the lowest: compounds 2, 1, 4 and 3 (each within the scatter of the next).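

Methoxy brings an oxygen and a hydrogen-bond acceptor to this aromatic carbon, yet in this assay its exchange for methyl gives a 1.1-fold lower number from compound 3 to compound 4 (0.03 log units; within the scatter) and its exchange for fluoro gives a 1.2-fold higher number from compound 2 to compound 4 (0.09 log units; within the scatter). Set against the 2-fluorophenyl group, 4-methoxyphenyl gives a 1.0-fold higher number from compound 1 to compound 4 (0.00 log units; within the scatter), so this position has now tolerated an added acceptor as well as methyl and fluoro without a step beyond the scatter. No evidence at hand accounts for this result.

As far as these compounds go, whether an amine or a carboxylic acid at this carbon, or a longer chain in place of methoxy, would move the number beyond the scatter stays open.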